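This account rests on a few compounds, and the source may have more. Where it says the series, first, only, none or still open, it means among the compounds named here.

Measured compounds:
compound 1 `CCOC(=O)c1sc(-c2cccc(NC(=O)c3cccc(F)c3)c2)nc1Nc1ccc(N2CCN(C)CC2)cc1` — in a functional assay on Raji cells (Homo sapiens) for antiproliferative activity, read by CCK-8 assay, with a stated time of 72 h (on this read-out higher numbers stand for weaker inhibition and lower numbers for stronger inhibition), compound 1 gives 21200 nM
compound 2 `CCOC(=O)c1sc(-c2cccc(NC(=O)c3ccc(F)c(Cl)c3)c2)nc1Nc1ccc(N2CCN(C)CC2)cc1` — in this assay compound 2 gives "not determined" (no result reported)
compound 3 `CCOC(=O)c1sc(-c2cccc(NC(=O)c3ccco3)c2)nc1Nc1ccc(N2CCN(C)CC2)cc1` — in this assay compound 3 gives 15100 nM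

Among the measured compounds shown here, only two numbers exist in this assay, and compound 1 holds one of them. Its number and that of compound 3 sit close together: the step of a 1.4-fold lower number from compound 1 to compound 3 (0.15 log units; within the scatter) is within the scatter, so nothing separates the two. Compound 2 contributes no number.

Compound 4 `CN1CCN(c2ccc(Nc3nc(-c4cccc(NC(=O)c5cccc(F)c5)c4)sc3C(=O)O)cc2)CC1` differs from compound 1 in one place: hydrogen in place of ethyl on an oxygen next to a carbonyl group. For the measured compounds named here, the one measured step, from compound 1 to compound 3, concerns a change on the carbonyl carbon of the amide and says nothing about the ester. Going by the values given here, no measured pair bears on the exchange of ethyl for hydrogen on that oxygen, so the expectation for compound 4 rests on compound 1 alone, with a wide margin. Compound 4 is estimated to give 30000 nM in this assay, within a range of 8000 nM to 150000 nM. This estimate means a step of a 1.4-fold higher number from compound 1 to compound 4 (0.15 log units; within the scatter), expected to fall inside the scatter, though a larger move in either direction cannot be excluded.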

Compound 4, half-maximal inhibitory concentration: 35100 nM
Compound 4: middle estimate off by 1.2-fold (0.07 log units), on the low side, within the range that was stated.
By their numbers in this assay, from the lowest: compounds 3, 1 and 4 (each within the scatter of the next, the first and the last beyond it).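

In this assay, the exchange of ethyl for hydrogen on an oxygen next to a carbonyl group, ethoxycarbonyl to carboxy, gives a 1.7-fold higher number from compound 1 to compound 4 (0.22 log units; within the scatter) and so stays within the scatter. Among the compounds shown here, this is the first reading at this position, as the earlier step concerned only the group on the amide carbonyl, and it shows that compound 1 and compound 4 cannot be told apart on this read-out, whether the ethyl is present or not. No measurement offered here accounts for this result.

The compounds shown leave open whether a methyl ester, a longer chain on that oxygen or a primary amide in place of the carboxy group would also stay within the scatter. They also leave open whether the same exchange would read alike with the furan-2-yl amide of compound 3.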